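The source may hold more compounds than are shown below. What is called first, only, known or untested is meant among the compounds shown, and "the series" means these compounds.

Measured so far, for the share of each compound bound to plasma protein:

compound 1, `O=C(NCc1ccc(F)cc1)c1ncc2cccnc2c1O`: 99.2%
compound 2, `CC(C)N1CC(c2nc(C(=O)NCc3ccc(F)cc3)c(O)c3ncccc23)CC1=O`: 97.8%
compound 3, `CN1CC(c2nc(C(=O)NCc3ccc(F)cc3S(C)(=O)=O)c(O)c3ncccc23)CC1=O`: 97%

In an ADME assay on a cell-free system (plasma, Homo sapiens) for protein binding, at pH 7.4, compound 2 stands second of the three on the unbound fraction. Its nearest neighbour is compound 3, whose value of 97% lies within the usual scatter of it. For the measured compounds named here, compound 1 is the furthest away, and the one measured step, a 2.8-fold higher unbound fraction from compound 1 to compound 2 (0.44 log units; beyond the scatter), lies beyond the scatter.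

Compound 4, `CCN1CC(c2nc(C(=O)NCc3ccc(F)cc3)c(O)c3ncccc23)CC1=O`, differs from compound 2 in one place: hydrogen in place of methyl on a saturated chain carbon bound to an amide-type nitrogen in a ring and a saturated chain carbon. Going by the values given here, no measured step follows such a change. Among the compounds with values here, the only step on hand added a whole 1-isopropyl-5-oxopyrrolidin-3-yl group to the shared core, a far larger change than the loss of one methyl, and compound 3 differs from compound 2 in two places at once. Trimming isopropyl to ethyl on the amide-type nitrogen is therefore expected to leave the binding about where it is, within the scatter: a 1.1-fold lower unbound fraction from compound 2 to compound 4 (0.04 log units; within the scatter). For compound 4 the estimate is 98%, expected to fall between 96.5% and 98.8%.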

Compound 4, plasma protein binding: 98.9%
For compound 4 the middle estimate is 1.8-fold (0.26 log units) (unbound fraction) above the measured one, and the stated range ends below it.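

In this assay, going from isopropyl to ethyl on the amide-type nitrogen gives a 2.0-fold lower unbound fraction from compound 2 to compound 4 (0.30 log units; within the scatter), so removing this one methyl produces no change that can be told from repeat-measurement noise. It also qualifies the earlier result: adding the isopropyl group's lactam substituent to the shared core gave a 2.8-fold higher unbound fraction from compound 1 to compound 2 (0.44 log units; beyond the scatter), whereas adding 1-ethyl-5-oxopyrrolidin-3-yl gives a 1.4-fold higher unbound fraction from compound 1 to compound 4 (0.14 log units; within the scatter), so the shift beyond the scatter does not carry over to the ethyl version, even though compound 2 and compound 4 cannot themselves be separated. Nothing available here offers an explanation for this difference.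

As far as these compounds go, what a longer chain, such as n-butyl, would do on that nitrogen remains open. So does the effect of a chain ending in an amine or a carboxylic acid.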